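Piperazine nitrogen substitution on the shared core

The compounds below may be only part of what the source reports. "The series", "measured", "known", "first", "only" and "open" are said of these compounds alone.

Compound 1 `COC(=O)c1ccc(C2SCC(=O)N2c2ccc(N3CCN(Cc4cccc([N+](=O)[O-])c4)CC3)cn2)c(OC)c1` gives > 100000 nM in a functional assay on NALM-6 cells (Homo sapiens) for antiproliferative activity, read by MTT assay and trypan blue exclusion, with a stated time of 72 h (a lower number here means a stronger inhibitor, a higher number a weaker inhibitor), which is a limit of the assay and not a number.
Compound 2 `COC(=O)c1ccc(C2SCC(=O)N2c2ccc(N3CCN(Cc4ccc(Cl)c(Cl)c4)CC3)cn2)c(OC)c1` gives > 100000 nM in this assay, again a limit of the assay.
Compound 3 `COC(=O)c1ccc(C2SCC(=O)N2c2ccc(N3CCNCC3)cn2)c(OC)c1` gives 9710 nM in this assay.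

Among the measured compounds shown here, compound 3, bearing hydrogen on the ring amine nitrogen, is the only member of the series with a measured number; the two benzyl-bearing compounds sit at a limit (the limit of > 100000 nM in this assay, at which 2 of the 3 values shown sit). The two readable steps both run in the same direction: an at least 10-fold lower number from compound 1 to compound 3 (1.01 log units; beyond the scatter) and an at least 10-fold lower number from compound 2 to compound 3 (1.01 log units; beyond the scatter), each large, so that removing a benzyl group from the ring nitrogen lowers the number by a large margin, and adding one raises it past what the assay can read. The step that the two limits leave unreadable from compound 1 to compound 2 is unreadable. Compound 4 `COC(=O)c1ccc(C2SCC(=O)N2c2ccc(N3CCN(S(=O)(=O)c4ccc([N+](=O)[O-])cc4)CC3)cn2)c(OC)c1` differs from compound 3 by (4-nitrophenyl)sulfonyl in place of hydrogen on an amine nitrogen in a ring. For the measured compounds named here, no measured compound carries a sulfonyl on this nitrogen, but every substituent placed there so far has moved the number up and out of range, and compound 4 is expected to follow, with a step of an 8.2-fold higher number from compound 3 to compound 4 (0.92 log units; beyond the scatter) in this assay. Compound 4 is therefore estimated at 80000 nM, within 20000 nM to 300000 nM, with a substantial chance that only a limit is reported.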

Compound 4, half-maximal inhibitory concentration: > 100000 nM
Compound 4 ended at the assay's limit (the forecaster's own chance of this, stated with the estimate: 55%); middle value at least 1.2-fold (0.09 log units) from the limit.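

With (4-nitrophenyl)sulfonyl in place of hydrogen on the ring amine nitrogen, this assay shows an at least 10-fold higher number from compound 3 to compound 4 (1.01 log units; beyond the scatter), so the large loss seen with the two benzyl groups also appears with a sulfonyl-linked aryl group and is not tied to the benzyl link. Among the four compounds shown, a measured number therefore stays with compound 3 alone, the only one with hydrogen on this nitrogen, and no compound goes against this, while the three substituted compounds all end at the same limit, which is a limit of the assay and not a number: the limit of > 100000 nM in this assay, at which 3 of the 4 values shown sit. The steps among compound 1, compound 2 and compound 4 cannot be read, so no order can be stated among 3-nitrobenzyl, 3,4-dichlorobenzyl and (4-nitrophenyl)sulfonyl.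

The compounds shown leave open whether any substituent on this nitrogen can keep a readable number, for instance a single methyl, an acetyl or a short chain ending in an amine. They also leave open how far the number of compound 3 can be moved elsewhere on the shared core, for instance with a carboxylic acid in place of the methyl ester.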